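A few compounds are considered here, and "the series" means these few. Any claim that something is new, unique, unknown or untested is made for them only; others in the source may bear on it.

Compound 1 `CCOC(=O)/C=C/c1ccncc1-c1ccc2cc[nH]c2c1` and compound 2 `O=C(/C=C/c1ccncc1-c1ccc2cc[nH]c2c1)N1CCOCC1` share one core. In an assay on a protein complex for inhibition of CDK8/Cyclin C (Homo sapiens), with a stated time of 1 h, tested at 10 uM (a higher number here means more inhibition at the concentration tested (going by the name of the read-out), a lower number less inhibition), compound 1 gives 104%, and compound 2 gives 102%. Between them there is only one change, (morpholin-4-yl in place of ethoxy on a carbonyl carbon), and the step it made was a number 2 percentage points lower from compound 1 to compound 2 (within the scatter). Compound 3 `CCOC(=O)/C=C/c1ccncc1-c1ccc2c(ccn2C)c1` carries a different core; the difference between the cores of compound 1 and compound 3 is not broken down here. In this assay compound 3 gives 100%. Compound 4 `Cn1ccc2cc(-c3cnccc3/C=C/C(=O)N3CCOCC3)ccc21` has not yet been measured. It differs from compound 3 by morpholin-4-yl in place of ethoxy on a carbonyl carbon, the same change already seen from compound 1 to compound 2. Because that earlier step was a number 2 percentage points lower from compound 1 to compound 2 (within the scatter), the expected step of a number 1 percentage points lower from compound 3 to compound 4 (within the scatter) is likewise small. For compound 4 the estimate in this assay is 99%, expected to fall between 91% and 106%.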

Compound 4, a percentage reported as inhibition, at one concentration (the size of the read-out at that concentration, not a potency): 97%
Estimate against measurement, compound 4: 2 percentage points above, within the range that was stated.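

In this assay, putting morpholin-4-yl in place of ethoxy on the carbonyl carbon gave a number 3 percentage points lower from compound 3 to compound 4 (within the scatter). The change therefore behaves alike on the two cores shown, with no step that stands out from the scatter on either: the same change on two cores in this assay, a number 2 percentage points lower (within the scatter) from compound 1 to compound 2 and a number 3 percentage points lower (within the scatter) from compound 3 to compound 4, 1 percentage points apart, within the scatter of two such steps. This does not show that the two cores respond alike in potency, as the read-out comes from a single concentration, and it says nothing about how the change would behave on any other core.

The compounds shown leave open how a carboxylic acid or a simple amine would read on the same carbonyl carbon. From the compounds shown here alone, a longer chain in place of ethoxy also remains open.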